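One More Chain Extension in a Cytotoxicity Series

The compounds below may be only part of what the source reports. "The series", "measured", "known", "first", "only" and "open" are said of these compounds alone.

Values measured in a functional assay on KB cells (Homo sapiens) for cytotoxicity, read by resazurin assay, with a stated time of 3 days; a higher number here means a weaker inhibitor, a lower number a stronger inhibitor
Compound 1 (`CCCCCC(=O)NCC(C)(C)CC1=C(O)C(=O)c2ccccc2C1=O`) gives 40200 nM
Compound 2 (`CCCCCCCCCCCCCC(=O)NCC(C)(C)CC1=C(O)C(=O)c2ccccc2C1=O`) gives 25100 nM

Compound 2 sits within the scatter of compound 1, so the two cannot be ranked. Compound 3 (`CCCCCCCCCCCCCCCCCC(=O)NCC(C)(C)CC1=C(O)C(=O)c2ccccc2C1=O`) differs from compound 2 in its chain (butyl in place of hydrogen on a saturated chain carbon, ten or more bonds along the chain from a carbonyl carbon). Among the compounds with values here, the only measured step that bears on this change, octyl in place of hydrogen (a 1.6-fold lower number from compound 1 to compound 2 (0.20 log units; within the scatter)), was small, so no shift beyond the scatter is expected in this assay in either direction. The estimated step is correspondingly small (a 1.0-fold lower number from compound 2 to compound 3 (0.00 log units; within the scatter)). Compound 3 is expected at 25000 nM (range 12000 nM to 50000 nM).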

Compound 3, half-maximal inhibitory concentration: 6350 nM
Compound 3: middle estimate off by 3.9-fold (0.60 log units), on the high side; measured number below the stated range.
By their numbers in this assay, from the lowest: compound 3; then compounds 2 and 1 (each within the scatter of the next).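

In this assay, butyl in place of hydrogen on a saturated chain carbon gives a 4.0-fold lower number from compound 2 to compound 3 (0.60 log units; beyond the scatter) and so moves the number beyond the scatter, which the octyl step did not do. The full dodecyl extension gives a 6.3-fold lower number from compound 1 to compound 3 (0.80 log units; beyond the scatter) in the same assay. Nothing measured here offers a reason for these steps.

Going by these compounds, whether a still longer chain would lower the number further stays open. So does how a chain carrying an amine or a carboxylic acid would read.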